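The compounds below may be only part of what the source reports. "The series", "measured", "known", "first", "only" and "open" are said of these compounds alone.

Among the measured compounds shown here, in a physicochemical assay for solubility, with a stated time of 18 h, at pH 7.4 (on this read-out lower numbers stand for lower solubility and higher numbers for higher solubility), compound 3 `COc1ccc(F)cc1CNCCCNc1ccnc2cc(Oc3ccc(Cl)cc3)ccc12` gives 14500 nM, the highest of the three numbers measured so far. Compound 1 `COc1ccc(F)cc1CNCCCNc1ccnc2cc(C3CCCCC3)ccc12` gives 4200 nM in this assay, and compound 2 `COc1ccc(F)cc1CNCCCNc1ccnc2cc(CC(C)C)ccc12` gives 4200 nM. The steps of a 3.5-fold higher number from compound 1 to compound 3 (0.54 log units; beyond the scatter) and a 3.5-fold higher number from compound 2 to compound 3 (0.54 log units; beyond the scatter) both brought a 4-chlorophenoxy group in place of an alkyl group on an aromatic carbon, whereas no change at the digits printed from compound 1 to compound 2 (within the scatter). Compound 4 `COc1ccc(F)cc1CNCCCNc1ccnc2cc(Oc3ccccc3OC)ccc12` differs from compound 3 by 2-methoxyphenyl in place of 4-chlorophenyl on an oxygen on an aromatic ring. For the measured compounds named here, none of the measured steps alters the ring that sits on that oxygen, so they only show that the phenoxy series sits high. For compound 4 the expected step is a 1.4-fold higher number from compound 3 to compound 4 (0.14 log units; within the scatter), not beyond the scatter. Compound 4 is therefore estimated to give 20000 nM in this assay, with a range from 7000 nM to 60000 nM.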

Compound 4, solubility: 14500 nM
Beside the measured number, compound 4's estimate is 1.4-fold (0.14 log units) above it, within the range that was stated.
By their numbers in this assay, from the lowest: compounds 1 and 2 (each within the scatter of the next); then compounds 3 and 4 (each within the scatter of the next).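

In this assay, among the compounds shown here, the first change to the ring on that oxygen, 4-chlorophenoxy to 2-methoxyphenoxy, gives no change at the digits printed from compound 3 to compound 4 (within the scatter). The higher level seen with compound 3 is therefore not tied to the 4-chlorophenyl ring: against the alkyl compounds the new ring also gives a 3.5-fold higher number from compound 2 to compound 4 (0.54 log units; beyond the scatter) and a 3.5-fold higher number from compound 1 to compound 4 (0.54 log units; beyond the scatter). No supporting measurement bears on why these numbers fall as they do.

Still open, as far as these compounds go, is whether a ring carrying an amine or a carboxylic acid in place of the chlorine or methoxy would stay at this level. From the compounds shown here alone, an unsubstituted phenoxy group is equally open.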